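A few compounds are considered here, and "the series" means these few. Any claim that something is new, unique, unknown or untested is made for them only; others in the source may bear on it.

Measured compounds:
compound 1 `COc1cc2c(Oc3ccc(NC(=O)c4nn(-c5ccccc5C)c(=O)cc4C)cc3F)ccnc2cc1OCCCN1CCN(C)CC1` gives 2830 nM
compound 2 `COc1cc2c(Oc3ccc(NC(=O)c4nn(-c5ccccc5C(F)(F)F)c(=O)cc4C)cc3F)ccnc2cc1OCCCN1CCCCC1` gives 140 nM
compound 3 `COc1cc2c(Oc3ccc(NC(=O)c4nn(-c5ccccc5C(F)(F)F)c(=O)cc4C)cc3F)ccnc2cc1OCCCN1CCC(C)CC1` gives 160 nM

In a functional assay on A549 cells (Homo sapiens) for inhibition, read by MTT assay, with a stated time of 72 h (on this read-out higher numbers stand for weaker inhibition and lower numbers for stronger inhibition), compound 3 holds the second highest of the three numbers. Its nearest neighbour is compound 2, whose value of 140 nM lies within the scatter of it; compound 1, with 2830 nM, lies far beyond the scatter on the weaker side.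

Compound 4 `COc1cc2c(Oc3ccc(NC(=O)c4nn(-c5ccccc5C(F)(F)F)c(=O)cc4C)cc3F)ccnc2cc1OCCCN1CCN(C)CC1` is reached from compound 3 by a single change: 4-methylpiperazin-1-yl in place of 4-methylpiperidin-1-yl on a saturated chain carbon, three bonds along the chain from an oxygen on an aromatic ring. Among the measured compounds shown here, the only measured step of the same kind, a 1.1-fold higher number from compound 2 to compound 3 (0.06 log units; within the scatter), concerned a methyl on the saturated ring and not the exchange of a ring carbon for a nitrogen, so it bears on the present change only loosely, suggesting that small edits to this ring are tolerated. Compound 1 also carries the 4-methylpiperazin-1-yl group, but it differs from compound 4 elsewhere, holding a methyl where compound 4 holds a trifluoromethyl, so its weak number cannot be tied to the ring change alone. The expected step of a 1.6-fold higher number from compound 3 to compound 4 (0.19 log units; within the scatter) is therefore small and not confidently beyond the scatter. Compound 4 is estimated at 250 nM, with a range from 80 nM to 800 nM.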

Compound 4, half-maximal inhibitory concentration: 170 nM
For compound 4 the middle estimate is 1.5-fold (0.17 log units) above the measured one; the measured number falls inside the stated range.
By their numbers in this assay, from the lowest: compounds 2, 3 and 4 (each within the scatter of the next); then compound 1.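

In this assay, 4-methylpiperazin-1-yl in place of 4-methylpiperidin-1-yl gives a 1.1-fold higher number from compound 3 to compound 4 (0.03 log units; within the scatter), and in place of piperidin-1-yl it gives a 1.2-fold higher number from compound 2 to compound 4 (0.08 log units; within the scatter), so with trifluoromethyl on the aromatic ring, these ring exchanges leave the number within the scatter. With the 4-methylpiperazin-1-yl group held fixed, trifluoromethyl in place of methyl on an aromatic carbon gives a 17-fold lower number from compound 1 to compound 4 (1.22 log units; beyond the scatter), so the large gap seen earlier goes with that edit and not with the ring. No supporting measurement accounts for either result.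

From the compounds shown here alone, it remains open whether a morpholin-4-yl ring, a dimethylamino group or a shorter ethyl chain would be tolerated at this position in the same way. Also open, going by these compounds, is how chlorine or methoxy would compare with trifluoromethyl on the aromatic ring.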